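A few compounds are considered here, and "the series" means these few. Any claim that something is new, unique, unknown or untested is made for them only; others in the source may bear on it.

Two compounds built on one shared core were tested in a functional assay on RD cells (Homo sapiens) for inhibition, read by luminescence and ATP content, with a stated time of 72 h; on this read-out lower numbers stand for higher toxicity in this test and higher numbers for lower toxicity in this test. Compound 1 `CCOC(=O)c1cnc2ccc(-c3ccc(N)cc3)cc2c1` carries an ethoxycarbonyl group, and in this assay compound 1 gives only a limit, > 7400 nM. Compound 2 `Cc1nc(-c2cnc3ccc(-c4ccc(N)cc4)cc3c2)no1` carries a 5-methyl-1,2,4-oxadiazol-3-yl group on that same aromatic carbon, and in this assay compound 2 also gives only a limit, > 2500 nM. The step that the two limits leave unreadable from compound 1 to compound 2 cannot be read in size or direction, since the limit of > 2500 nM in this assay, at which 1 of the 2 values shown sits, and the limit of > 7400 nM in this assay, at which 1 of the 2 values shown sits, cap both values. Among the compounds with values here, compound 2 therefore stands at a limit, with no number to place it; the one further value shown is a limit as well.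

Compound 3 `Cc1nc(-c2cnc3ccc(-c4ccccc4)cc3c2)no1` differs from compound 2 by hydrogen in place of amino on an aromatic carbon. Within the data shown here, no measured step touches this change, and the only measured step, a step that the two limits leave unreadable from compound 1 to compound 2, gives neither size nor direction. The expectation for compound 3 therefore rests solely on the two limits of compound 1 and compound 2, and the step from compound 2 to compound 3 is estimated as a step that the limit leaves unreadable from compound 2 to compound 3. Compound 3 is expected to give about 10000 nM in this assay, within a range from 2500 nM to 40000 nM, most likely reported again only as a limit.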

Compound 3, half-maximal cytotoxic concentration: > 2500 nM
Compound 3 gave a limit, no number (the forecaster's own chance of this, stated with the estimate: 75%); the middle value is on the limit's open side.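

Compound 2 and compound 3 give only limits in this assay, so no new step can be read between them: the limit of > 2500 nM in this assay, at which 2 of the 3 values shown sit.

The compounds shown leave open whether hydrogen in place of amino changes toxicity in this test at all, and at what actual number any of the three compounds would fall.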